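A few compounds are considered here, and "the series" means these few. Any claim that something is new, unique, unknown or untested is made for them only; others in the source may bear on it.

Measured in a functional assay on NCI-H727 cells (Homo sapiens) for cytotoxicity, with a stated time of 48 h; on this read-out higher numbers stand for weaker inhibition and lower numbers for stronger inhibition:
- compound 1 `COc1cccc(/C=C/C(=O)c2c(OC)cc(OC)cc2OC)c1`: 8200 nM
- compound 2 `COc1cc(OC)c(C(=O)/C=C/c2ccccc2)c(OC)c1`: 11400 nM
- compound 3 `COc1cc(OC)c(C(=O)/C=C/c2ccc(F)cc2)c(OC)c1`: 5500 nM

Compound 3 gives 5500 nM, and its nearest neighbour in the set differs only slightly: a 1.5-fold lower number from compound 1 to compound 3 (0.17 log units; within the scatter). Its clearer gap is a 2.1-fold lower number from compound 2 to compound 3 (0.32 log units; beyond the scatter), a modest step in which fluoro takes the place of hydrogen on an aromatic carbon.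

Compound 4 `COc1cc(OC)c(C(=O)/C=C/c2ccc(Br)cc2)c(OC)c1` has not yet been measured. It keeps the shared core of compound 3 and changes one atom: bromo in place of fluoro on an aromatic carbon. Among the compounds with values here, no measured compound carries bromo, so the data offer no direct guide. Within the data shown here, the closest evidence is a 2.1-fold lower number from compound 2 to compound 3 (0.32 log units; beyond the scatter), the only measured change at this place, and it is small. A swap of one halogen for another should therefore move the number little in this assay. The expected step is a 1.1-fold lower number from compound 3 to compound 4 (0.04 log units; within the scatter), which is no real change beyond the scatter. The estimate for compound 4 is 5000 nM, with an expected range from 2300 nM to 11000 nM.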

Compound 4, half-maximal inhibitory concentration: 11300 nM
Estimate against measurement, compound 4: 2.3-fold (0.35 log units) below; the measured number lies above the stated range.
By their numbers in this assay, from the lowest: compounds 3, 1, 4 and 2 (each within the scatter of the next, the first and the last beyond it).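

In this assay, one halogen cannot simply stand in for another at this place: bromo in place of fluoro gives a 2.1-fold higher number from compound 3 to compound 4 (0.31 log units; beyond the scatter), a modest step, so the benefit seen with fluoro does not carry over to bromo. Bromo in place of hydrogen gives a 1.0-fold lower number from compound 2 to compound 4 (0.00 log units; within the scatter), and 4-bromophenyl in place of 3-methoxyphenyl gives a 1.4-fold higher number from compound 1 to compound 4 (0.14 log units; within the scatter); both steps lie within the scatter, so compound 4 cannot be told apart from either of these two compounds. No measurement here explains why the two halogens differ.

The compounds shown leave open whether chloro at this place would read like fluoro or like bromo. They also leave open how an amine or a carboxylic acid on this ring would compare with the halogens.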